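The source may hold more compounds than are shown below. What is called first, only, known or untested is meant among the compounds shown, and "the series" means these compounds.

Compound 1, `CC(O)c1cccc(C(=O)N[C@@H](C)Cn2ccc(-c3ccc(C#N)c(Cl)c3)n2)c1`, gives in an ADME assay on PC-3 cells (Homo sapiens) for cytotoxicity, read by CCK-8 assay, with a stated time of 6 days (a higher number here means a weaker inhibitor, a lower number a stronger inhibitor), the value > 30000 nM, which is a limit of the assay and not a number.
Compound 2, `CC(=O)c1ccc(C(=O)N[C@@H](C)Cn2ccc(-c3ccc(C#N)c(Cl)c3)n2)cc1`, gives in this assay the value > 30000 nM, again a limit and not a number.

Within the data shown here, compound 2 therefore stands at the limit of this assay, and the one further value shown is a limit too. Among the measured compounds shown here, the only measured step, a step that the two limits leave unreadable from compound 1 to compound 2, cannot be read in either direction, since both of its ends are limits; what is known is only that (the limit of > 30000 nM in this assay, at which 2 of the 2 values shown sit).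

Compound 3, `C[C@@H](Cn1ccc(-c2ccc(C#N)c(Cl)c2)n1)NC(=O)c1ccccc1F`, differs from compound 2 in one place: 2-fluorophenyl in place of 4-acetylphenyl on a carbonyl carbon. For the measured compounds named here, no measured step bears directly on this exchange. Both measured compounds sit at the same limit, and the replacement of one aromatic substituent on the carbonyl carbon by another gives no ground to expect a reading inside the range of the assay. The step from compound 2 to compound 3 is therefore estimated as a step that the limit leaves unreadable from compound 2 to compound 3, that is, no movement beyond the scatter. Compound 3 is expected to give about 40000 nM in this assay, within 15000 nM to 100000 nM, most likely again reported only as a limit.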

Compound 3, half-maximal inhibitory concentration: > 30000 nM
Compound 3 ended at the assay's limit (the forecaster's own chance of this, stated with the estimate: 80%); the middle value does not contradict the limit.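

No new step can be read from compound 3: its steps to compound 1 and compound 2 join limits at both ends, so neither can be sized or given a direction, and all that stands is this: the limit of > 30000 nM in this assay, at which 3 of the 3 values shown sit.

The compounds shown leave open how these three compare in this assay and whether any group on the carbonyl carbon would give a reading inside its range.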